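Adding a second chloro to compound 2

The source may report more compounds than this note shows. Statements on the series, on what has been measured and on what is new or still open speak of the compounds shown alone.

Compound 1 `O=S1(=O)C=Cc2cccc(Nc3ccc(OC(F)(F)F)cc3)c21`, compound 2 `O=S1(=O)C=Cc2cccc(Nc3ccc(Cl)cc3)c21` and compound 3 `COc1ccc(Nc2cccc3c2S(=O)(=O)C=C3)cc1` share one core and differ in a single group: trifluoromethoxy, chloro or methoxy. In a functional assay on MDA-MB-231 cells (Homo sapiens) for antiproliferative activity, read by MTT assay, with a stated time of 72 h (a lower number here means a stronger inhibitor, a higher number a weaker inhibitor), compound 1 gives 2100 nM, compound 2 gives 1210 nM and compound 3 gives 1040 nM. Compound 2 cannot be separated from either of the others, as the steps show: a 1.7-fold lower number from compound 1 to compound 2 (0.24 log units; within the scatter), and a 1.2-fold lower number from compound 2 to compound 3 (0.07 log units; within the scatter).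

Compound 4 `O=S1(=O)C=Cc2cccc(Nc3ccc(Cl)c(Cl)c3)c21` keeps the chloro of compound 2 and gains another: chloro in place of hydrogen on an aromatic carbon. Going by the values given here, no measured step adds a group to an aromatic carbon that carried only hydrogen, since all three swap one group for another, so they offer only indirect guidance. The largest of them, a 2.0-fold lower number from compound 1 to compound 3 (0.31 log units; beyond the scatter), is modest, so no step beyond the scatter is expected in this assay, though the uncertainty is wide. The expected change is a 1.1-fold lower number from compound 2 to compound 4 (0.04 log units; within the scatter). For compound 4 the estimated value is 1100 nM, with an expected range of 500 nM to 2400 nM.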

Compound 4, half-maximal inhibitory concentration: 1360 nM
Beside the measured number, compound 4's estimate is 1.2-fold (0.09 log units) below it, within the range that was stated.
By their numbers in this assay, from the lowest: compounds 3, 2, 4 and 1 (each within the scatter of the next, the first and the last beyond it).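

Going by these compounds alone, the earlier compounds only swapped one group for another, so compound 4 is the first to show what happens when a chloro replaces hydrogen on an aromatic carbon, here ortho to a chloro group: in this assay the result is a 1.1-fold higher number from compound 2 to compound 4 (0.05 log units; within the scatter). This position therefore accepts a chloro with no change that can be told apart from repeat-measurement noise, though that rests on one group in one assay. No measurement is available that could explain this result.

From the compounds shown here alone, it remains open whether a different group on this same carbon, such as an amine, a carboxylic acid or a longer chain, would move the number beyond the scatter. It is also unknown whether this added chloro would behave the same alongside methoxy or trifluoromethoxy instead of the first chloro.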